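Swapping a methoxyphenyl for a fluorobenzyl on the quinoline core

This account rests on a few compounds, and the source may have more. Where it says the series, first, only, none or still open, it means among the compounds named here.

For the measured compounds named here, compound 3 `COc1ccc(-c2ccc3c(NCCCNCc4ccco4)ccnc3c2)cc1` stands at the top of the three numbers so far in an ADME assay for permeability, using PAMPA, with a stated time of 30 min, at pH 7.4 (on this read-out higher numbers stand for higher permeability and lower numbers for lower permeability), where compound 3 gives 237 10^-6 cm/s. Compound 1 `CC(C)CCc1ccc2c(NCCCNCc3ccco3)ccnc2c1` gives 23 10^-6 cm/s in this assay, and compound 2 `COc1ccc(F)cc1CNCCCNc1ccnc2cc(Cc3ccc(F)cc3)ccc12` gives 23 10^-6 cm/s in this assay. Going by the values given here, the one single-point step recorded so far, a 10-fold higher number from compound 1 to compound 3 (1.01 log units; beyond the scatter), shows how far the 4-methoxyphenyl lifted the read-out relative to isopentyl on the same aromatic carbon.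

Compound 4 `Fc1ccc(Cc2ccc3c(NCCCNCc4ccco4)ccnc3c2)cc1` is the next step from compound 3, and the change is 4-fluorobenzyl in place of 4-methoxyphenyl on an aromatic carbon. Among the compounds with values here, no measured pair isolates this exact exchange. The step of a 10-fold higher number from compound 1 to compound 3 (1.01 log units; beyond the scatter) shows that what sits on this aromatic carbon can move the number a great deal, and compound 2, which carries a 4-fluorobenzyl on its core but a different amine side chain, gives 23 10^-6 cm/s in this assay. Taken together these suggest that compound 4 is expected to fall below compound 3, with a step estimated at a 5.9-fold lower number from compound 3 to compound 4 (0.77 log units; beyond the scatter). Compound 4 is therefore estimated at 40 10^-6 cm/s in this assay, with a range from 15 10^-6 cm/s to 120 10^-6 cm/s.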

Compound 4, apparent permeability: 23 10^-6 cm/s
Compound 4: middle estimate off by 1.7-fold (0.24 log units), on the high side, and the stated range covers the measured number.
By their numbers in this assay, from the lowest: compounds 1, 2 and 4 (each within the scatter of the next); then compound 3.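

In this assay the exchange of 4-methoxyphenyl for 4-fluorobenzyl on the aromatic carbon, with the furan-2-yl side chain held constant, gives a 10-fold lower number from compound 3 to compound 4 (1.01 log units; beyond the scatter) even though both groups count the same number of heavy atoms and one six-membered aromatic ring. The side chain does not move the number when 4-fluorobenzyl sits on the core: furan-2-yl in place of 5-fluoro-2-methoxyphenyl gives no change at the digits printed from compound 2 to compound 4 (within the scatter) in this comparison. The isopentyl and 4-fluorobenzyl groups also stand level, with 4-fluorophenyl in place of isobutyl giving no change at the digits printed from compound 1 to compound 4 (within the scatter) here, so among the three groups seen on this carbon with the furan-2-yl side chain, only the 4-methoxyphenyl of compound 3 stands apart. Nothing given here accounts for that gap.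

The compounds shown leave open whether the high number of compound 3 goes with the methoxy group or with an aryl ring bound straight to the core, which a plain phenyl or a 4-methoxybenzyl on the same carbon would separate. They also leave open whether the 5-fluoro-2-methoxyphenyl side chain would match furan-2-yl with 4-methoxyphenyl on the core.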